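This account rests on a few compounds, and the source may have more. Where it says the series, first, only, none or still open, it means among the compounds named here.

Within the data shown here, compound 3 `C/C(=N\NC(=O)COc1cccc2ccccc12)c1ccccc1Br` gives 79.8 ug/mL in an ADME assay on MT4 cells (Homo sapiens) for cytotoxicity, read by MTT assay, with a stated time of 4 days (on this read-out lower numbers stand for higher toxicity in this test and higher numbers for lower toxicity in this test), the highest of the three numbers measured so far. Compound 1 `C/C(=N\NC(=O)COc1cccc2ccccc12)c1cccc([N+](=O)[O-])c1`, with 3-nitrophenyl on the carbon with a double bond to nitrogen, gives 12.1 ug/mL in this assay; compound 2 `C/C(=N\NC(=O)COc1cccc2ccccc12)c1ccc(C#N)cc1Br`, with 2-bromo-4-cyanophenyl at the same carbon, gives 12.1 ug/mL. Compound 3 is set apart from both by a 6.6-fold higher number from compound 1 to compound 3 (0.82 log units; beyond the scatter) and a 6.6-fold higher number from compound 2 to compound 3 (0.82 log units; beyond the scatter), while between the other two there is no change at the digits printed from compound 1 to compound 2 (within the scatter).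

Compound 4 `C/C(=N\NC(=O)COc1cccc2ccccc12)c1ccc([N+](=O)[O-])cc1` differs from compound 3 by 4-nitrophenyl in place of 2-bromophenyl on a carbon with a double bond to nitrogen. Among the measured compounds shown here, the one measured step that bears on this is a 6.6-fold higher number from compound 1 to compound 3 (0.82 log units; beyond the scatter), in which a nitrophenyl gave way to 2-bromophenyl; compound 4 runs that exchange backwards, though with 4-nitrophenyl instead of 3-nitrophenyl, so no measured pair covers the exact group. A fall of about the same size in this assay is therefore expected, a 5.3-fold lower number from compound 3 to compound 4 (0.73 log units; beyond the scatter). Compound 4 is estimated at 15 ug/mL, with a likely range from 6 ug/mL to 45 ug/mL.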

Compound 4, half-maximal cytotoxic concentration: 89.3 ug/mL
Beside the measured number, compound 4's estimate is 6.0-fold (0.77 log units) below it; measured number outside the range, above it.
By their numbers in this assay, from the lowest: compounds 1 and 2 (each within the scatter of the next); then compounds 3 and 4 (each within the scatter of the next).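

With a nitro-bearing ring on the carbon with a double bond to nitrogen, the number in this assay depends on which nitrophenyl is present: 4-nitrophenyl in place of 3-nitrophenyl gives a 7.4-fold higher number from compound 1 to compound 4 (0.87 log units; beyond the scatter). Exchanging 2-bromophenyl for 4-nitrophenyl gives a 1.1-fold higher number from compound 3 to compound 4 (0.05 log units; within the scatter), and 4-nitrophenyl in place of 2-bromo-4-cyanophenyl gives a 7.4-fold higher number from compound 2 to compound 4 (0.87 log units; beyond the scatter), so these four compounds form two groups, compound 3 with compound 4 and compound 1 with compound 2, and a nitro group occurs in both. No measurement at hand accounts for the separation between 4-nitrophenyl and 3-nitrophenyl.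

As far as these compounds go, it remains open whether 2-nitrophenyl or 4-cyanophenyl at this carbon would fall with compound 3 and compound 4 or with compound 1 and compound 2. Also open, from the compounds shown here alone, is how an amine or a carboxylic acid on this ring would read in this assay.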